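Trifluoromethyl in Place of Ethoxy on the Outer Ring

The source may report more compounds than this note shows. Statements on the series, on what has been measured and on what is new or still open speak of the compounds shown alone.

Compound 1 `CC1CC/C(=N\Nc2ccc(Br)cc2)c2ncc(C(=O)O)c(=O)n21`: 0.8 umol/kg
Compound 2 `CC1CC/C(=N\Nc2ccc(O)cc2)c2ncc(C(=O)O)c(=O)n21`: 1.7 umol/kg
Compound 3 `CCOc1ccc(N/N=C2\CCC(C)n3c2ncc(C(=O)O)c3=O)cc1`: 1.6 umol/kg

Three measured compounds share one core and differ only in the group carried on an aromatic carbon of the outer ring. In a functional assay on the whole organism for inhibition, with Rattus norvegicus as the target (on this read-out higher numbers stand for an effect only at larger amounts of compound and lower numbers for an effect already at smaller amounts), compound 1 gives 0.8 umol/kg, compound 2 gives 1.7 umol/kg and compound 3 gives 1.6 umol/kg. Compound 3 holds the second highest of the three numbers; its gap to compound 2 and its gap to compound 1 both lie within the usual scatter of repeated measurements.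

Compound 4 `CC1CC/C(=N\Nc2ccc(C(F)(F)F)cc2)c2ncc(C(=O)O)c(=O)n21` has not been measured. trifluoromethyl in place of ethoxy on an aromatic carbon

Within the data shown here, no measured step brings in a trifluoromethyl group, so none matches this change directly. The nearest guide is a 2.0-fold higher number from compound 1 to compound 3 (0.30 log units; within the scatter), which shows that exchanging the group on this carbon shifted the number only a little; a 2.1-fold higher number from compound 1 to compound 2 (0.33 log units; beyond the scatter) and a 1.1-fold lower number from compound 2 to compound 3 (0.03 log units; within the scatter) point the same way. For compound 4 a step of a 1.5-fold lower number from compound 3 to compound 4 (0.16 log units; within the scatter) is therefore expected, with no firm direction. Compound 4 is estimated at 1.1 umol/kg, within a range from 0.4 umol/kg to 3 umol/kg.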

Compound 4, dose for 50% inhibition: 38.6 umol/kg
The estimate for compound 4 lay 35-fold (1.55 log units) below the measured number; measured number outside the range, above it.
By their numbers in this assay, from the lowest: compounds 1, 3 and 2 (each within the scatter of the next, the first and the last beyond it); then compound 4.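

Bromo, hydroxy and ethoxy on this aromatic carbon had differed only modestly, so the position looked forgiving, but in this assay trifluoromethyl breaks from all three. In place of ethoxy it gives a 24-fold higher number from compound 3 to compound 4 (1.38 log units; beyond the scatter), in place of hydroxy a 23-fold higher number from compound 2 to compound 4 (1.36 log units; beyond the scatter) and in place of bromo a 48-fold higher number from compound 1 to compound 4 (1.68 log units; beyond the scatter) on the same carbon, so with the shared core unchanged, this single exchange means that far more compound is needed for the same effect. Nothing available explains why this group stands apart from the other three.

From the compounds shown here alone, it remains open whether trifluoromethyl is an isolated case or whether other groups on this carbon, such as a nitrile, an amine, a carboxylic acid or a longer chain, would also raise the number this far.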